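The source may report more compounds than this note shows. Statements on the series, on what has been measured and on what is new or still open speak of the compounds shown alone.

Two compounds of this series have a number in an ADME assay on NIH3T3 cells (Mus musculus) for cytotoxicity, read by MTT assay, with a stated time of 24 h; on this read-out higher numbers stand for weaker inhibition and lower numbers for stronger inhibition. Compound 1 `Cn1nnnc1SCC(=O)N/N=c1/scc(-c2ccc(C#N)cc2)n1-c1ccccc1` gives 213 ug/mL in this assay and stands as the lower of the two numbers; compound 2 `N#Cc1ccc(-c2cs/c(=N/NC(=O)CSc3nnnn3-c3ccccc3)n2-c2ccccc2)cc1` gives 453 ug/mL in this assay. Within the data shown here, the only measured step, a 2.1-fold higher number from compound 1 to compound 2 (0.33 log units; beyond the scatter), is a modest one and concerns a phenyl in place of methyl on an aromatic nitrogen.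

Compound 3 `Cn1nnnc1SCC(=O)N/N=c1/scc(-c2ccccc2)n1-c1ccccc1` differs from compound 1 by hydrogen in place of cyano on an aromatic carbon; read one bond further out, this is 4-cyanophenyl to phenyl. Among the measured compounds shown here, no measured step touches this position, so the step from compound 1 to compound 2 gives no direct guide and only sets a scale for what single changes have done. A step of no more than modest size, in either direction, is therefore expected, with no sound basis for a direction. Compound 3 is estimated at 250 ug/mL in this assay, within 120 ug/mL to 520 ug/mL, which means an expected step of a 1.2-fold higher number from compound 1 to compound 3 (0.07 log units; within the scatter).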

Compound 3, half-maximal inhibitory concentration: 173 ug/mL
For compound 3 the middle estimate is 1.4-fold (0.16 log units) above the measured one; measured number inside the range.
By their numbers in this assay, from the lowest: compounds 3 and 1 (each within the scatter of the next); then compound 2.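

In this assay, among these compounds, the change from 4-cyanophenyl to phenyl comes to a 1.2-fold lower number from compound 1 to compound 3 (0.09 log units; within the scatter) and gives the first reading of this position, where the earlier pair spoke only to the group on the aromatic nitrogen. With methyl held on that nitrogen, this read-out does not tell cyano from hydrogen on this aromatic carbon, para to a large group, so the nitrile is not needed to keep the number in this range. No available measurement bears on why the two compounds read alike.

From the compounds shown here alone, whether an amine or a carboxylic acid on this carbon would also stay within the scatter of hydrogen and cyano remains open. Also open, going by these compounds, is whether cyano and hydrogen still read alike with phenyl in place of methyl on the aromatic nitrogen.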